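Methoxy for Methylamino on a Furan-Bearing Nucleoside Core

The source may hold more compounds than are shown below. What is called first, only, known or untested is meant among the compounds shown, and "the series" means these compounds.

Measured compounds:
compound 1 `C#Cc1cn([C@@H]2O[C@H](CO)[C@@H](O)[C@H]2O)c2ncnc(NC)c12`; compound 2 `C#Cc1cn([C@@H]2O[C@H](CO)[C@@H](O)[C@H]2O)c2ncnc(OC)c12`; compound 3 `CNc1ncnc2c1c(-c1ccco1)cn2[C@@H]1O[C@H](CO)[C@@H](O)[C@H]1O`.

In a functional assay on HCT-116 cells (Homo sapiens), read by MTT assay, with a stated time of 72 h (a higher number here means a weaker inhibitor, a lower number a stronger inhibitor), compound 1 gives > 20000 nM, which is a limit of the assay and not a number (the limit of > 20000 nM in this assay, at which 1 of the 3 values shown sits). In this assay compound 2 gives 4060 nM. In this assay compound 3 gives 230 nM, the lowest of the two numbers.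

The change from compound 1 to compound 2 is methoxy in place of methylamino on an aromatic carbon, and it made an at least 4.9-fold lower number from compound 1 to compound 2 (0.69 log units; beyond the scatter). The two cores differ by furan-2-yl in place of ethynyl on an aromatic carbon, a change that made an at least 86-fold lower number from compound 1 to compound 3 (1.93 log units; beyond the scatter).

Compound 4 `COc1ncnc2c1c(-c1ccco1)cn2[C@@H]1O[C@H](CO)[C@@H](O)[C@H]1O` is not yet measured. It differs from compound 3 by methoxy in place of methylamino on an aromatic carbon, the same change as that from compound 1 to compound 2, at the same place. Because compound 1 sits at a limit (the limit of > 20000 nM in this assay, at which 1 of the 3 values shown sits), the true size of that earlier step is not known; only its least size is. On the furan-bearing core the step is expected to run in the same direction and is estimated as a 2.3-fold lower number from compound 3 to compound 4 (0.36 log units; beyond the scatter). In this assay compound 4 is therefore expected to give about 100 nM, within 25 nM to 500 nM.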

Compound 4, half-maximal inhibitory concentration: 40 nM
Compound 4: the middle estimate sits 2.5-fold (0.40 log units) above what was measured; low and high end bracket the measured number.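

In this assay, methoxy in place of methylamino on the furan-bearing core gave a 5.8-fold lower number from compound 3 to compound 4 (0.76 log units; beyond the scatter), and furan-2-yl in place of ethynyl on the methoxy-bearing core gave a 100-fold lower number from compound 2 to compound 4 (2.01 log units; beyond the scatter). The methoxy change therefore kept its direction from one core to the other: the same change on two cores in this assay, an at least 4.9-fold lower number (0.69 log units; beyond the scatter) from compound 1 to compound 2 and a 5.8-fold lower number (0.76 log units; beyond the scatter) from compound 3 to compound 4; the limit leaves it open whether they differ. The furan-2-yl change kept its direction too, but whether either change also kept its size is not shown: the same change on two cores in this assay, an at least 86-fold lower number (1.93 log units; beyond the scatter) from compound 1 to compound 3 and a 100-fold lower number (2.01 log units; beyond the scatter) from compound 2 to compound 4; the limit leaves it open whether they differ.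

The compounds shown leave open what other groups on the same aromatic carbon would do, such as an unsubstituted amine, an ethoxy group or a longer chain, and what a phenyl or thiophene ring would do in place of ethynyl or furan-2-yl. Within the data shown here, with only two cores and a single cell assay here, it also remains open whether these steps would hold on a third core or in other cells.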